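Cyclopropyl for Methyl on the Pyrazole of Compound 3

The source may hold more compounds than are shown below. What is called first, only, known or untested is meant among the compounds shown, and "the series" means these compounds.

Of the compounds shown here, three have so far been measured in an assay on HEK293F cells for inhibition of cholesterol 24-hydroxylase (Homo sapiens), read by trypan blue exclusion, with stated times of 15 min and 5 h; a higher number here means a weaker inhibitor, a lower number a stronger inhibitor. Compound 1 `O=C(NC1CC1)c1ccc(-c2cnccc2-c2ccccc2)cc1` gives 74 nM. Compound 2 `CCN(C)C(=O)C1CCN(c2cncnc2-c2ccccc2)CC1` gives 14 nM. Compound 3 `Cc1cnn(-c2ccncc2N2CCC(C(=O)N(C)C)CC2)c1` gives 8.5 nM, the lowest number of the three. The gap between compound 3 and compound 2 lies within the usual scatter of repeated measurements, so the two cannot be told apart on these numbers alone; the gap between compound 3 and compound 1, by contrast, lies beyond that scatter, so compound 3 is clearly the stronger of those two.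

Compound 4 `CN(C)C(=O)C1CCN(c2cnccc2-n2cc(C3CC3)cn2)CC1` has not yet been measured in this assay. It differs from compound 3 in one place only: cyclopropyl in place of methyl on an aromatic carbon. For the measured compounds named here, no pair of measured compounds differs by this same change, so there is no measured step to lean on. The change adds no hydrogen-bond donor, no hydrogen-bond acceptor and no charge, and the rest of the molecule stays as it is in compound 3. A small move, if any, seems the likely outcome. The step of a 1.2-fold lower number from compound 3 to compound 4 (0.08 log units; within the scatter) is expected to stay within the scatter, leaning slightly toward a lower number. Compound 4 is therefore estimated to give about 7 nM, with a range from 3 nM to 18 nM.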

Compound 4, half-maximal inhibitory concentration in the cholesterol 24-hydroxylase assay: 12 nM
Beside the measured number, compound 4's estimate is 1.7-fold (0.23 log units) below it, and the stated range covers the measured number.
By their numbers in the cholesterol 24-hydroxylase assay, from the lowest: compounds 3, 4 and 2 (each within the scatter of the next); then compound 1.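

In the cholesterol 24-hydroxylase assay, cyclopropyl in place of methyl on this aromatic carbon of the pyrazole gives a 1.4-fold higher number from compound 3 to compound 4 (0.15 log units; within the scatter), so compound 3 and compound 4 cannot be told apart, and this position accepts the larger group with its three-membered ring without a readable loss of inhibition. For the compounds shown here, no two of the earlier compounds differed in one place only, so they could not show what this pair shows: a single change that leaves inhibition within the scatter can still move lipophilicity beyond it, as a physicochemical assay for lipophilicity, at pH 7.4 (on this read-out lower numbers stand for lower lipophilicity and higher numbers for higher lipophilicity), records: the measured distribution coefficient of compound 3, 1.6, and of compound 4, 2.1, a number 0.50 log units higher (beyond the scatter) In the physicochemical assay compound 3 gives 1.6 and compound 4 gives 2.1 as measured values. This rests on one pair, so it describes this position and this change, not a general rule.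

The compounds shown leave open whether an amine or a carboxylic acid on the same aromatic carbon would keep inhibition close to that of compound 3 while giving a lower number in the physicochemical assay. They also leave open how much size this position can take, since a tert-butyl or a phenyl group there could give a quite different number in the cholesterol 24-hydroxylase assay.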